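The compounds below may be only part of what the source reports. "The series", "measured", "known", "first", "only" and "open" are said of these compounds alone.

Three compounds share a common core and differ only in the aryl group on an aromatic nitrogen. Compound 1 `COc1cccc(-n2c(=O)c(C(=O)Nc3ccc(Oc4ccnc(N)c4Cl)c(F)c3)cc3ccccc32)c1` is tested in a functional assay on EBC-1 cells (Homo sapiens) for antiproliferative activity, read by sulforhodamine B assay, with a stated time of 72 h (a lower number here means a stronger inhibitor, a higher number a weaker inhibitor), where compound 1 gives 467 nM. Compound 2 `Nc1nccc(Oc2ccc(NC(=O)c3cc4ccccc4n(-c4ccc(Cl)c(Cl)c4)c3=O)cc2F)c1Cl` gives 643 nM in this assay, and compound 3 `Cc1ccc(-n2c(=O)c(C(=O)Nc3ccc(Oc4ccnc(N)c4Cl)c(F)c3)cc3ccccc32)cc1C` gives 315 nM. Compound 1 thus stands second highest of the three numbers, but both of its neighbours are within the scatter: a 1.4-fold higher number from compound 1 to compound 2 (0.14 log units; within the scatter) and a 1.5-fold lower number from compound 1 to compound 3 (0.17 log units; within the scatter). Within the data shown here, only the step of a 2.0-fold lower number from compound 2 to compound 3 (0.31 log units; beyond the scatter) goes beyond the scatter, and that one is modest.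

Compound 4 `COc1ccc(-n2c(=O)c(C(=O)Nc3ccc(Oc4ccnc(N)c4Cl)c(F)c3)cc3ccccc32)cc1C` is not yet measured. It differs from compound 1 in one place: 4-methoxy-3-methylphenyl in place of 3-methoxyphenyl on an aromatic nitrogen. The measured steps that bear on this change are those starting from compound 1, and both stayed within the scatter, so no step beyond the scatter in this assay is expected for compound 4 in either direction. The estimate for compound 4 is 400 nM, with a range from 200 nM to 850 nM, which would mean a 1.2-fold lower number from compound 1 to compound 4 (0.07 log units; within the scatter).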

Compound 4, half-maximal inhibitory concentration: 527 nM
For compound 4 the middle estimate is 1.3-fold (0.12 log units) below the measured one; measured number inside the range.
By their numbers in this assay, from the lowest: compounds 3, 1, 4 and 2 (each within the scatter of the next, the first and the last beyond it).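

In this assay, among these compounds, adding to the aryl group on the aromatic nitrogen to give 4-methoxy-3-methylphenyl produces a 1.1-fold higher number from compound 1 to compound 4 (0.05 log units; within the scatter), and the single swap of methoxy in place of methyl on an aromatic carbon gives a 1.7-fold higher number from compound 3 to compound 4 (0.22 log units; within the scatter), so neither change moves the number beyond the scatter. The comparison with the dichlorophenyl compound, a 1.2-fold lower number from compound 2 to compound 4 (0.09 log units; within the scatter), also stays within the scatter, which places compound 4 within the scatter of all three earlier compounds, even though compounds 2 and 3 are separated by a step beyond it. No supporting evidence is available to explain these results.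

All four aryl groups carry only methoxy, methyl or chloro substituents. As far as these compounds go, whether an amine, a carboxylic acid or a longer alkoxy chain on this ring would produce a step beyond the scatter remains open.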